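The source may hold more compounds than are shown below. What is called first, only, known or untested is meant among the compounds shown, and "the series" means these compounds.

The measured compounds:

Compound 1, `CC#CCn1c(N2CCC[C@@H](N)C2)nc2c1c(=O)n(Cc1c(Br)cccc1C(=O)O)c(=O)n2C`. In an ADME assay on isolated protein for inhibition of Dipeptidyl peptidase 9 (Homo sapiens), with stated times of 15 min, 60 s and 20 min (on this read-out lower numbers stand for stronger inhibition and higher numbers for weaker inhibition), compound 1 gives only a limit, > 100000 nM.
Compound 2, `CC#CCn1c(N2CCC[C@@H](N)C2)nc2c1c(=O)n(Cc1cc(C#N)ccc1C(=O)O)c(=O)n2C`. In this assay compound 2 gives only a limit, > 100000 nM.
Compound 3, `CC#CCn1c(N2CCC[C@@H](N)C2)nc2c1c(=O)n(Cc1ccc(Br)cc1C(=O)O)c(=O)n2C`. In this assay compound 3 gives only a limit, > 100000 nM.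

Compound 3 therefore stands where every measured compound here stands: at the limit of this assay, with no number behind it. That is the whole of the evidence, (the limit of > 100000 nM in this assay, at which 3 of the 3 values shown sit). The three steps among the measured compounds, a step that the two limits leave unreadable from compound 1 to compound 2, a step that the two limits leave unreadable from compound 1 to compound 3 and a step that the two limits leave unreadable from compound 2 to compound 3, cannot be sized, since each joins two limits.

Compound 4, `CC#CCn1c(N2CCC[C@@H](N)C2)nc2c1c(=O)n(Cc1cc(Cl)ccc1C(=O)OC)c(=O)n2C`, has not yet been measured in this assay. It differs from compound 3 in one place: 5-chloro-2-(methoxycarbonyl)phenyl in place of 4-bromo-2-carboxyphenyl on a saturated chain carbon bound to an aromatic nitrogen. Going by the values given here, none of the measured steps offers a readable size for such a change, and all three bear on it only by showing limits at both ends. What is expected is therefore no step beyond the scatter, and most probably another limit rather than a number.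

Compound 4 is accordingly expected to sit near 100000 nM, between 30000 nM and 300000 nM, which would mean an estimated step of a number no higher from compound 3 to compound 4 (the limit leaves the size open).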

Compound 4, half-maximal inhibitory concentration: > 100000 nM
Compound 4 gave a limit, no number (the forecaster's own chance of this, stated with the estimate: 80%); the middle value sits exactly at the limit.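

In this assay compound 4 gives only a limit, > 100000 nM. Its steps to compounds 1, 2 and 3 cannot be read, since each joins two limits. The compounds shown leave open how strong the inhibition of any of them is, and whether any of these changes alters it: the limit of > 100000 nM in this assay, at which 4 of the 4 values shown sit.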